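The source may hold more compounds than are shown below. What is called first, only, known or untested is meant among the compounds shown, and "the series" means these compounds.

Measured compounds:
compound 1, `O=C(Nc1nnc(-c2ccc(Cl)cc2)s1)c1c(Cl)cccc1Cl`, 380 nM in a functional assay on the whole organism (integument) for inhibition, with Chilo suppressalis as the target, read by scintillation counting, with a stated time of 72 h; on this read-out higher numbers stand for weaker inhibition and lower numbers for stronger inhibition
compound 2, `O=C(Nc1nnc(-c2ccc(Cl)cc2)s1)c1ccccc1C(F)(F)F`
compound 3, `COc1cccc(OC)c1C(=O)Nc1nnc(-c2ccc(C(C)C)cc2)s1`, 398 nM

In this assay compound 2 reaches only a limit, > 16500 nM, and no number is reported for it. Of the two numbers that are known, compound 3 holds the higher one, but its nearest neighbour, compound 1, sits so close that the gap lies within the scatter, so the two cannot be told apart.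

The next compound, compound 4 `COc1cccc(OC)c1C(=O)Nc1nnc(-c2ccc(I)cc2)s1`, has not yet been measured. It differs from compound 3 in one place: iodo in place of isopropyl on an aromatic carbon, or in other words iodo in place of isopropyl on an aromatic carbon. Going by the values given here, no measured pair shows this exchange, so there is no step to lean on. The nearest hint is that compound 1, which carries a different group at that part of the molecule, gives a number indistinguishable from compound 3. The expected step of a 1.0-fold higher number from compound 3 to compound 4 (0.00 log units; within the scatter) is therefore small, without a clear direction, and not beyond the scatter. Compound 4 is estimated at 400 nM, within 150 nM to 1200 nM.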

Compound 4, half-maximal inhibitory concentration: 89.1 nM
The estimate for compound 4 lay 4.5-fold (0.65 log units) above the measured number, and the stated range ends above it.
By their numbers in this assay, from the lowest: compound 4; then compounds 1 and 3 (each within the scatter of the next). At a limit, above all of these: compound 2.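

Going by these compounds alone, until now, no two compounds differing in one place had been compared in this assay so nothing showed whether the group on this aromatic carbon matters. Replacing isopropyl with iodo gives a 4.5-fold lower number from compound 3 to compound 4 (0.65 log units; beyond the scatter) and so shows that this position responds to change. Here a single iodine atom gives stronger inhibition than the three-carbon group it replaces, although nothing measured here explains the difference.

The compounds shown leave open how other groups at this place, such as bromo, an amine or a carboxylic acid, would compare with iodo and isopropyl. They also leave open whether iodo would give a similar step with a different group in place of the two methoxy groups that compounds 3 and 4 share.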